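The compounds below may be only part of what the source reports. "The series", "measured", "known", "first", "only" and "open" are said of these compounds alone.

In a functional assay on A-375 cells (Homo sapiens) for cytotoxicity, read by MTT assay (on this read-out higher numbers stand for weaker inhibition and lower numbers for stronger inhibition), compound 1 (`COc1ccc(/C=C/C(=O)c2ccc(OC)c3c2OC(C)(C)C=C3)cc1OC(=O)C(C)C`) gives 310 nM and compound 2 (`C=CC(=O)Oc1cc(/C=C/C(=O)c2ccc(OC)c3c2OC(C)(C)C=C3)ccc1OC`) gives 390 nM, so the two stand level within the scatter. Compound 3 (`COc1ccc(/C=C/C(=O)Oc2cc(/C=C/C(=O)c3ccc(OC)c4c3OC(C)(C)C=C4)ccc2OC)cc1`) keeps the core of compound 2 but has 2-(4-methoxyphenyl)ethenyl in place of vinyl on a carbonyl carbon. Going by the values given here, the only measured step at this carbonyl carbon is a 1.3-fold higher number from compound 1 to compound 2 (0.10 log units; within the scatter), where vinyl replaced isopropyl. Among the compounds with values here, that small step is the sole guide, and the data hold no example of a group like the entering one at this place. A modest loss of inhibition is therefore expected, with wide uncertainty. The step estimated in this assay is a 1.5-fold higher number from compound 2 to compound 3 (0.19 log units; within the scatter). For compound 3 the expected value is 600 nM, with an estimated range of 150 nM to 2500 nM.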

Compound 3, half-maximal inhibitory concentration: 2630 nM
For compound 3 the middle estimate is 4.4-fold (0.64 log units) below the measured one; measured number outside the range, above it.
By their numbers in this assay, from the lowest: compounds 1 and 2 (each within the scatter of the next); then compound 3.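

In this assay, the carbonyl carbon proved sensitive to what it carries: 2-(4-methoxyphenyl)ethenyl in place of vinyl gives a 6.7-fold higher number from compound 2 to compound 3 (0.83 log units; beyond the scatter) and in place of isopropyl gives an 8.5-fold higher number from compound 1 to compound 3 (0.93 log units; beyond the scatter) at this place. Going by these compounds alone, the exchange of isopropyl for vinyl had stayed within the scatter, so this is the first change here to go beyond it, and it weakens inhibition. No measurement shown accounts for this loss.

The compounds shown do not separate the six-membered aromatic ring from its methoxy group, so a plain 2-phenylethenyl group or a saturated 2-(4-methoxyphenyl)ethyl chain could tell these apart. On these data alone, how an amine or a carboxylic acid would read on this carbonyl carbon also stays open.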